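Removing the chloro from compound 1

The source may report more compounds than this note shows. Statements on the series, on what has been measured and on what is new or still open speak of the compounds shown alone.

Compound 1 `CNC(=O)c1cc(C(=O)N[C@H]2CC[C@H](O)CC2)n([C@@H](C)c2cccc(Cl)c2)n1`: 3.7
Compound 2 `CNC(=O)c1cc(C(=O)N[C@H]2[C@@H]3C[C@H](O)C[C@@H]32)n([C@@H](C)c2cccc(Cl)c2)n1`: 3.7
Compound 3 `CNC(=O)c1cc(C(=O)N[C@H]2CC[C@H](O)CC2)c([C@@H](C)c2cccc(OC)c2)o1`: 2.9
Compound 4 `CNC(=O)c1cc(C(=O)N[C@H]2CC[C@H](O)CC2)n([C@@H](C)c2ccccc2)n1`: not yet measured

In a physicochemical assay for lipophilicity (on this read-out lower numbers stand for lower lipophilicity and higher numbers for higher lipophilicity), compound 1 gives 3.7, level with compound 2, while compound 3 lies clearly lower at 2.9. Compound 3 differs from compound 1 in more than one place, so that gap cannot be tied to any single change.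

The step to compound 4 is hydrogen in place of chloro on an aromatic carbon. For the measured compounds named here, the only measured single-place step, no change at the digits printed from compound 1 to compound 2 (within the scatter), concerns the group on an amide-type nitrogen, so it bears only indirectly on a change at an aromatic carbon. Going by the values given here, no measured pair shows hydrogen in place of chloro, and the expectation therefore rests on the structural change itself, starting from compound 1 at 3.7. In this assay the expected step is downward and beyond the scatter, a number 0.60 log units lower from compound 1 to compound 4 (beyond the scatter). For compound 4 the estimated value is 3.1, with an expected range from 2.7 to 3.5.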

Compound 4, distribution coefficient: 2.9
Compound 4: the middle estimate sits 0.20 log units above what was measured; measured number inside the range.
By their numbers in this assay, from the lowest: compounds 3 and 4 (each within the scatter of the next); then compounds 1 and 2 (each within the scatter of the next).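

In this assay, for the compounds shown here, the change from 3-chlorophenyl to phenyl gives a number 0.80 log units lower from compound 1 to compound 4 (beyond the scatter) and is the first single-place step here to go beyond the scatter. The only earlier such step, no change at the digits printed from compound 1 to compound 2 (within the scatter), concerned the group on an amide-type nitrogen, so this aromatic carbon is the first place shown where one change moves the number, with a single chlorine atom leaving. Nothing available explains the size of this step.

What the compounds leave open is how other groups at this aromatic carbon, such as fluoro, a nitrile or an amine, would stand against chloro and hydrogen. Going by these compounds, it also remains open whether hydrogen in place of chloro would give a step of similar size on a core other than that of compound 1.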